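Methyl Additions on a Curcumin-like Benzimidazole Dienone Series

The source may hold more compounds than are shown below. What is called first, only, known or untested is meant among the compounds shown, and "the series" means these compounds.

The measured compounds:
compound 1, `COc1cc(/C=C/C(=O)/C=C/c2nc3ccccc3n2C)ccc1O`, 3700 nM
compound 2, `COc1cc(/C=C/C(=O)/C=C/c2nc3cc(C)ccc3n2C)ccc1O`, 4500 nM
compound 3, `COc1ccc(/C=C/C(=O)/C=C/c2nc3c(C)cccc3n2C)cc1O`, 7400 nM

All three were tested in a functional assay on MCF7 cells (Homo sapiens) for cytotoxicity, read by MTT assay, with a stated time of 48 h; a higher number here means a weaker inhibitor, a lower number a stronger inhibitor. Compound 1 gives 3700 nM, and compound 2, which differs from it by methyl in place of hydrogen on an aromatic carbon, gives 4500 nM. That step, a 1.2-fold higher number from compound 1 to compound 2 (0.09 log units; within the scatter), is small and within the scatter. Compound 3 gives 7400 nM in this assay , and its nearest neighbour is compound 2; the gaps from compound 3 to compound 2 and to compound 1 are both within the scatter, so the three stand together. How the core of compound 3 differs from the core of compound 1 is not broken down here.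

Compound 4, `COc1ccc(/C=C/C(=O)/C=C/c2nc3c(C)c(C)ccc3n2C)cc1O`, has not been measured in this assay . It differs from compound 3 by methyl in place of hydrogen on an aromatic carbon. This is the same kind of change as that from compound 1 to compound 2, though the surroundings differ: in compound 4 the entering methyl sits ortho to a methyl group (1 heavy atom), whereas in compound 2 it does not. Because the earlier step of a 1.2-fold higher number from compound 1 to compound 2 (0.09 log units; within the scatter) was within the scatter, compound 4 is expected to show a similar small step, a 1.1-fold higher number from compound 3 to compound 4 (0.06 log units; within the scatter). The estimate for compound 4 in this assay is 8500 nM, expected to fall between 4500 nM and 16000 nM.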

Compound 4, half-maximal inhibitory concentration: 3500 nM
Compound 4: middle estimate off by 2.4-fold (0.39 log units), on the high side; the whole stated range lies above it.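

In this assay, methyl in place of hydrogen on an aromatic carbon, here ortho to a methyl group, gives a 2.1-fold lower number from compound 3 to compound 4 (0.33 log units; beyond the scatter), a modest step towards a stronger inhibitor. Set beside the earlier step, the same change on the other core cannot be told apart from it: the same change on two cores in this assay, a 1.2-fold higher number (0.09 log units; within the scatter) from compound 1 to compound 2 and a 2.1-fold lower number (0.33 log units; beyond the scatter) from compound 3 to compound 4, 2.6-fold (0.41 log units) apart, within the scatter of two such steps. Only the newer step lies beyond the scatter on its own, but this does not show that the change acts differently on the two cores or that the neighbouring methyl group decides its outcome, and two steps are equally too few to show that its effect carries unchanged from one core to another.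

The compounds shown leave open whether a larger or different group on this aromatic carbon, such as an ethyl chain, a chlorine atom or an amine, would give a step of similar size. They also leave open whether methyl in place of hydrogen would give a comparable step on further cores in the series, so its size on any new core remains loosely bounded for now.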